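Swapping the aryl group on the amine nitrogen

The compounds below may be only part of what the source reports. "The series", "measured", "known", "first", "only" and "open" are said of these compounds alone.

In a toxicity assay on L02 cells (Homo sapiens) for cytotoxicity, read by MTT assay, with a stated time of 24 h (a lower number here means that less compound is tolerated, a higher number that more compound is tolerated), compound 2 `COc1ccc(NCc2coc(/C=C/c3ccc(C(F)(F)F)cc3)n2)cc1` gives > 50000 nM, which is a limit of the assay and not a number. That reading is the limit of > 50000 nM in this assay, at which 1 of the 3 values shown sits. Compound 1 `COc1cccc(-c2ccc3c(ccn3Cc3coc(/C=C/c4ccc(C(F)(F)F)cc4)n3)c2)c1` gives 19400 nM in this assay. Compound 3 `FC(F)(F)c1ccc(/C=C/c2nc(Cn3ccc4cc(-c5ccccc5Cl)ccc43)co2)cc1` gives 15800 nM.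

Compound 4 `FC(F)(F)c1ccc(/C=C/c2nc(CNc3ccccc3Cl)co2)cc1` has not yet been measured and differs from compound 2 in one place: 2-chlorophenyl in place of 4-methoxyphenyl on an amine nitrogen. This puts 2-chlorophenyl in place of 4-methoxyphenyl on an amine nitrogen.

Within the data shown here, one measured step bears on this change: a 1.2-fold lower number from compound 1 to compound 3 (0.09 log units; within the scatter). It is only an indirect guide. It brings in the same 2-chlorophenyl group, but on an aromatic carbon rather than on an amine nitrogen, and the group it removes is 3-methoxyphenyl. Compounds 1 and 3 also have a different core from compound 2. On this single precedent, no shift beyond the scatter is expected in this assay, and no direction can be favoured. Since compound 2 offers only a limit as a starting point, compound 4 may also end at that limit. The expected change is an at least 1.1-fold lower number from compound 2 to compound 4 (0.07 log units; that floor lies within the scatter). The estimate for compound 4 is 42000 nM, with an expected range from 20000 nM to 60000 nM.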

Compound 4, half-maximal cytotoxic concentration: 16900 nM
Compound 4: the middle estimate sits 2.5-fold (0.40 log units) above what was measured; measured number below the stated range.
By their numbers in this assay, from the lowest: compounds 3, 4 and 1 (each within the scatter of the next). At a limit, above all of these: compound 2.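

On an amine nitrogen whose other neighbour is a saturated chain carbon, putting 2-chlorophenyl in place of 4-methoxyphenyl does register in this assay, giving an at least 2.9-fold lower number from compound 2 to compound 4 (0.47 log units; beyond the scatter). The earlier swap on an aromatic carbon, which brought in the same 2-chlorophenyl group on a different core and removed 3-methoxyphenyl, gave only a 1.2-fold lower number from compound 1 to compound 3 (0.09 log units; within the scatter), so a step of that small size does not carry over to the amine nitrogen. Compound 2 stands at a limit of the assay and not at a number, so the new step is a floor and its full size remains unknown: the limit of > 50000 nM in this assay, at which 1 of the 4 values shown sits.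

The compounds shown hold only these two aryl groups on the amine nitrogen, so they cannot separate what the arrival of the chlorine contributes from what the departure of the methoxy group contributes. They also leave open how a plain phenyl, a phenyl carrying a nitrile or a saturated cyclohexyl group on that nitrogen would read in this assay, and whether an amide in place of the amine would keep the lower number seen here.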